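The compounds below may be only part of what the source reports. "The series", "measured", "known", "first", "only" and "open" are said of these compounds alone.

Measured compounds: compound 1 `N#CC1=C(N)Oc2c(N)cc3nc4ccccc4nc3c2C12C(=O)N(Cc1cnnn1-c1ccc(Cl)cc1)c1ccccc12` and compound 2 `Cc1ccc(C)c(-n2nncc2CN2C(=O)C3(C(C#N)=C(N)Oc4c(N)cc5nc6ccccc6nc5c43)c3ccccc32)c1`.

In a functional assay on MCF7 cells (Homo sapiens) for antiproliferative activity, read by MTT assay, with a stated time of 48 h (on this read-out lower numbers stand for stronger inhibition and higher numbers for weaker inhibition), compound 1 gives only > 50000 nM, which is a limit of the assay and not a number. Compound 2 likewise gives only the limit > 50000 nM. The step that the two limits leave unreadable from compound 1 to compound 2 is therefore unreadable, since both values sit at the limit of > 50000 nM in this assay, at which 2 of the 2 values shown sit. Compound 3 `N#CC1=C(N)Oc2c(N)cc3nc4ccccc4nc3c2C12C(=O)N(Cc1cnnn1-c1ccc(Cl)cc1Cl)c1ccccc12` differs from compound 2 by 2,4-dichlorophenyl in place of 2,5-dimethylphenyl on an aromatic nitrogen. Among the measured compounds shown here, no measured step gives a readable size or direction for this change, so the expected step of a number no higher from compound 2 to compound 3 (the limit leaves the size open) is taken as none beyond the scatter. Compound 3 is accordingly expected to give about 50000 nM, within 20000 nM to 100000 nM, most likely again as a limit.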

Compound 3, half-maximal inhibitory concentration: > 50000 nM
Compound 3 gave a limit, no number (the forecaster's own chance of this, stated with the estimate: 85%); the middle value lies on the limit itself.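

No step can be read among compound 1, compound 2 and compound 3, because each gives a limit and not a number: the limit of > 50000 nM in this assay, at which 3 of the 3 values shown sit. From the compounds shown here alone, what remains open is whether the groups on the aromatic nitrogen differ in this assay at all.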